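Halogen swap on the urea aryl of a sulfonamide urea

The compounds below may be only part of what the source reports. "The series", "measured", "known", "first", "only" and "open" are said of these compounds alone.

Two ureas sharing one core have been characterised in an assay on Sf9 cells for displacement of a labelled ligand from P2Y purinoceptor 1 (Homo sapiens); on this read-out lower numbers stand for stronger inhibition and higher numbers for weaker inhibition. Compound 1 `Cc1noc(NS(=O)(=O)c2ccc(NC(=O)Nc3ccc(C(F)(F)F)cc3)cc2)c1C` gives 45000 nM in this assay, and compound 2 `Cc1noc(NS(=O)(=O)c2ccc(NC(=O)Nc3cc(Cl)cc(Cl)c3)cc2)c1C` gives 27000 nM. Within the data shown here, compound 2 therefore carries the lowest of the two numbers, yet its only neighbour is compound 1, and the step of a 1.7-fold lower number from compound 1 to compound 2 (0.22 log units; within the scatter) stays within the scatter, so the two compounds cannot be told apart on these data.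

Compound 3 `Cc1noc(NS(=O)(=O)c2ccc(NC(=O)Nc3cc(F)cc(F)c3)cc2)c1C` differs from compound 2 in one place: 3,5-difluorophenyl in place of 3,5-dichlorophenyl on an amide-type nitrogen. Among the measured compounds shown here, no measured step exchanges one halogen for another on this aryl group; the one step available, a 1.7-fold lower number from compound 1 to compound 2 (0.22 log units; within the scatter), replaced a 4-(trifluoromethyl)phenyl by the 3,5-dichlorophenyl and changed the number by less than the scatter. On that basis no step beyond the scatter is expected in this assay for the change from compound 2 to compound 3, though a move toward a higher number is held slightly more likely than the reverse. The estimated step is a 1.3-fold higher number from compound 2 to compound 3 (0.11 log units; within the scatter). For compound 3 the expected inhibition constant is 35000 nM, with a range from 12000 nM to 100000 nM.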

Compound 3, inhibition constant: >= 100000 nM
Compound 3: only a limit was reported (the forecaster's own chance of this, stated with the estimate: 10%); middle value at least 2.8-fold (0.45 log units) from the limit.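

In this assay the aryl group on the amide-type nitrogen now shows a step beyond the scatter, which the earlier pair did not: 3,5-difluorophenyl in place of 3,5-dichlorophenyl gives an at least 3.7-fold higher number from compound 2 to compound 3 (0.56 log units; beyond the scatter). Set against the 4-(trifluoromethyl)phenyl, the same 3,5-difluorophenyl gives an at least 2.2-fold higher number from compound 1 to compound 3 (0.34 log units; beyond the scatter), so compound 3 stands apart from both earlier ureas, although those two remain within the scatter of each other. The reading for compound 3 rests on a limit and not on a number: the limit of >= 100000 nM in this assay, at which 1 of the 3 values shown sits.

As far as these compounds go, how far compound 3 lies past that limit stays open, and with it the full size of both steps. Also open, from the compounds shown here alone, is how the number would respond to a 3,5-dibromophenyl or a plain phenyl in the same place, which could show whether the two halogens of compound 2 and compound 3 mark the ends of a series or whether the chlorine-to-fluorine exchange is a special case.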